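The source may report more compounds than this note shows. Statements on the series, on what has been measured and on what is new or still open speak of the compounds shown alone.

Compound 1, `C=C1CN/C(=N/c2ccccc2)S1`: in a functional assay on MCF7 cells (Homo sapiens) for antiproliferative activity, read by MTT assay, with a stated time of 72 h (on this read-out lower numbers stand for stronger inhibition and higher numbers for weaker inhibition), compound 1 reaches only the limit > 100000 nM.
Compound 2, `COc1ccc(/C=C2/CN(C)/C(=N/c3ccc(Cl)cc3)S2)cc1`: in this assay compound 2 gives 7600 nM.
Compound 3, `COc1ccc(/C=C2\S/C(=N\c3ccccc3)N(C)C2=O)cc1`: in this assay compound 3 reaches only the limit > 100000 nM.

Among the compounds with values here, compound 2 stands as the only measured number in this set; the other two values are limits of the assay, as the limit of > 100000 nM in this assay, at which 2 of the 3 values shown sit, shows. Compound 4, `COc1ccc(/C=C2/CN(C)/C(=N/c3ccc(OC)cc3)S2)cc1`, has not yet been measured. It differs from compound 2 in one place: methoxy in place of chloro on an aromatic carbon. Within the data shown here, no measured pair differs in a single place, so there is no measured step to lean on. The expectation is a small step in this assay, not clearly beyond the scatter, leaning toward slightly weaker inhibition. Compound 4 is expected to give 11000 nM, between 3500 nM and 35000 nM. The step from compound 2 to compound 4 that this estimate means is a 1.4-fold higher number from compound 2 to compound 4 (0.16 log units; within the scatter).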

Compound 4, half-maximal inhibitory concentration: 8700 nM
Estimate against measurement, compound 4: 1.3-fold (0.10 log units) above; the measured number falls inside the stated range.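

Within the data shown here, this is the first step between two measured compounds that differ in one place. In this assay methoxy in place of chloro, on an aromatic carbon para to a large group, gives a 1.1-fold higher number from compound 2 to compound 4 (0.06 log units; within the scatter) and so the two groups cannot be told apart here. A measurable number at this position therefore does not rest on the chlorine alone, since compound 4 holds one without it.

As far as these compounds go, whether an amine, a carboxylic acid or a longer chain at this position would read the same stays open. Nothing among the data shown bears on why chloro and methoxy read alike.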